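The source may report more compounds than this note shows. Statements on the series, on what has been measured and on what is new or still open speak of the compounds shown alone.

Measured so far:
compound 1, `O=c1[nH]cc(S(=O)(=O)Nc2cccc(-c3cn(-c4cccc(F)c4)nn3)c2)c(=O)[nH]1`, in a functional assay on HepG2 cells (Homo sapiens) for antiproliferative activity, read by MTT assay, with a stated time of 24 h; on this read-out higher numbers stand for weaker inhibition and lower numbers for stronger inhibition: > 20000 nM
compound 2, `O=c1[nH]cc(S(=O)(=O)Nc2cccc(-c3cn(-c4ccc(F)cc4)nn3)c2)c(=O)[nH]1`, in this assay: > 20000 nM

The value of compound 1 is a limit of the assay, not a number. The value of compound 2 is likewise a limit of the assay. The step that the two limits leave unreadable from compound 1 to compound 2 therefore cannot be read in either direction. Both compounds sit at the limit of > 20000 nM in this assay, at which 2 of the 2 values shown sit, so compound 2 stands at the limit of this assay, with no number to place it above or below compound 1.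

Compound 3, `O=c1[nH]cc(S(=O)(=O)Nc2cccc(-c3cn(-c4cccc(Cl)c4)nn3)c2)c(=O)[nH]1`, differs from compound 2 by 3-chlorophenyl in place of 4-fluorophenyl on an aromatic nitrogen. For the measured compounds named here, the only measured step, from compound 1 to compound 2, bears on the same position and is unreadable, so there is no measured step to size the change for compound 3 against. The change exchanges one halogenated phenyl for another on the same ring nitrogen, and both measured compounds with such groups stay at the limit. Compound 3 is therefore expected to remain near the limit, at about 25000 nM, between 8000 nM and 80000 nM. The expected step is a step that the limit leaves unreadable from compound 2 to compound 3, which is no step beyond the scatter.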

Compound 3, half-maximal inhibitory concentration: 4200 nM
Estimate against measurement, compound 3: 6.0-fold (0.77 log units) above; measured number below the stated range.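

Chloro in place of fluoro on an aromatic carbon gives an at least 4.7-fold lower number from compound 1 to compound 3 (0.67 log units; beyond the scatter) in this assay, so the halogen on the phenyl group carried by the aromatic nitrogen changes the read-out when 3-fluorophenyl becomes 3-chlorophenyl. The change of 3-chlorophenyl in place of 4-fluorophenyl gives an at least 4.7-fold lower number from compound 2 to compound 3 (0.67 log units; beyond the scatter), but this step alters both the halogen and its place on the phenyl ring and cannot separate the two. The step between compound 1 and compound 2 cannot be read, and both steps to compound 3 start from a limit of the assay, not from a number: the limit of > 20000 nM in this assay, at which 2 of the 3 values shown sit.

The compounds shown leave open whether the readable value belongs to chloro as such or would also appear with bromo or methyl on the phenyl ring, and whether 4-chlorophenyl would separate the effect of the halogen from that of its place. They also leave open the full size of both steps and how an amine or a carboxylic acid on the same phenyl ring would read in this assay.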